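Coumarin hydrazone series: removing one benzyloxy group

The compounds below may be only part of what the source reports. "The series", "measured", "known", "first", "only" and "open" are said of these compounds alone.

Measured compounds and values in a functional assay, read by spectrophotometry, with a stated time of 5 min; on this read-out higher numbers stand for weaker inhibition and lower numbers for stronger inhibition:
compound 1 `Nc1ccccc1/N=C\c1cc(=O)oc2cc(OCc3ccccc3)ccc12`: 217000 nM
compound 2 `O=c1cc(/C=N\c2ccccc2O)c2ccc(OCc3ccccc3)cc2o1`: 469000 nM
compound 3 `N/N=C\c1cc(=O)oc2cc(OCc3ccccc3)cc(OCc3ccccc3)c12`: 36500 nM

Compound 3 gives the lowest number of the three in this assay; compound 1 stands nearest to it and compound 2 furthest. Compound 3 differs from compound 1 and from compound 2 in more than one place, so their values are only compared side by side, without a single step between them. Among the compounds with values here, the one step measured, a 2.2-fold higher number from compound 1 to compound 2 (0.33 log units; beyond the scatter), concerns the group on the imine aryl ring and does not touch a benzyloxy group.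

Compound 4 `N/N=C\c1cc(=O)oc2cc(OCc3ccccc3)ccc12` is not yet measured. Its change from compound 3 is hydrogen in place of benzyloxy on an aromatic carbon. Within the data shown here, no measured step bears on this change; the hydrazone is kept, and only a benzyloxy group is removed. The expectation therefore rests on the values of compound 1 and compound 2, which carry a single benzyloxy group and show higher numbers than compound 3, and is taken as a modest rise for compound 4, expected as a 1.9-fold higher number from compound 3 to compound 4 (0.28 log units; within the scatter). Compound 4 is estimated at 70000 nM in this assay, with a range from 20000 nM to 250000 nM.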

Compound 4, half-maximal inhibitory concentration: 131000 nM
Estimate against measurement, compound 4: 1.9-fold (0.27 log units) below, and the stated range covers the measured number.
By their numbers in this assay, from the lowest: compound 3; then compounds 4 and 1 (each within the scatter of the next); then compound 2.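

In this assay, within the data shown here, the only single-place step at the carbon ortho to a fused ring is a 3.6-fold higher number from compound 3 to compound 4 (0.55 log units; beyond the scatter), so with the hydrazone kept, the benzyloxy group at this carbon has a measurable bearing on the number. On the double-bonded nitrogen, amino can now be set against two aryl groups: 2-hydroxyphenyl gives a 3.6-fold lower number from compound 2 to compound 4 (0.55 log units; beyond the scatter), whereas 2-aminophenyl gives a 1.7-fold lower number from compound 1 to compound 4 (0.22 log units; within the scatter), so the two aryl groups do not read alike against amino. Nothing available here accounts for either result.

Open, as far as these compounds go, is where a methoxy group or an amine on this carbon would fall relative to compound 3 and compound 4. Also open, from the compounds shown here alone, is whether the benzyloxy step carries over to cores bearing 2-aminophenyl or 2-hydroxyphenyl on the double-bonded nitrogen.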